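The source may hold more compounds than are shown below. What is called first, only, known or untested is meant among the compounds shown, and "the series" means these compounds.

In a physicochemical assay, with a stated time of 30 min (a higher number here means a weaker inhibitor, a lower number a stronger inhibitor), three compounds sharing one core have been measured. Compound 1 (`COc1cc2c(cc1OC)C(=O)C(C(=O)Nc1ccccc1)C2`) gives 61.3 ug/mL, compound 2 (`COc1ccc(NC(=O)C2Cc3cc(OC)c(OC)cc3C2=O)cc1`) gives 49.5 ug/mL, and compound 3 (`COc1cc2c(cc1OC)C(=O)C(C(=O)Nc1cccc(Cl)c1)C2`) gives 76.3 ug/mL. Compound 2 therefore stands within the scatter of both others, as the two steps that reach it show: a 1.2-fold lower number from compound 1 to compound 2 (0.09 log units; within the scatter) and a 1.5-fold higher number from compound 2 to compound 3 (0.19 log units; within the scatter).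

Compound 4 (`COc1cc2c(cc1OC)C(=O)C(C(=O)Nc1ccccc1C)C2`) has not yet been measured. It differs from compound 2 on an amide-type nitrogen, where 2-methylphenyl replaces 4-methoxyphenyl: 2-methylphenyl in place of 4-methoxyphenyl on an amide-type nitrogen. For the measured compounds named here, no measured compound carries 2-methylphenyl, so the evidence is indirect. Going by the values given here, the closest precedent is the other exchange of this group, a 1.5-fold higher number from compound 2 to compound 3 (0.19 log units; within the scatter), and the step with chloro in place of hydrogen, a 1.2-fold higher number from compound 1 to compound 3 (0.10 log units; within the scatter), is equally small. On these steps, no change beyond the scatter is expected in this assay. For compound 4 the estimated value is 60 ug/mL, with an expected range from 35 ug/mL to 100 ug/mL. This estimate means a 1.2-fold higher number from compound 2 to compound 4 (0.08 log units; within the scatter), a step expected to stay within the scatter.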

Compound 4, half-maximal inhibitory concentration: 43.7 ug/mL
Compound 4: the middle estimate sits 1.4-fold (0.14 log units) above what was measured; measured number inside the range.
By their numbers in this assay, from the lowest: compounds 4, 2, 1 and 3 (each within the scatter of the next).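

For the compounds shown here, the result extends what the earlier compounds showed to a third kind of aryl group on the amide-type nitrogen: in this assay, 2-methylphenyl stays within the scatter of 4-methoxyphenyl (a 1.1-fold lower number from compound 2 to compound 4 (0.05 log units; within the scatter)), of 3-chlorophenyl (a 1.7-fold lower number from compound 3 to compound 4 (0.24 log units; within the scatter)) and of the plain phenyl group (a 1.4-fold lower number from compound 1 to compound 4 (0.15 log units; within the scatter)). The exchange for 4-methoxyphenyl also replaces a group with 1 hydrogen-bond acceptor by one with 0, and no change beyond the scatter follows, so across these four compounds none of the exchanges on this aryl group separates one compound from another. Nothing shown accounts for these small steps.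

The compounds shown leave open whether a carboxylic acid or an amine on this phenyl ring, or a cyclohexyl group in its place, would move the number beyond the scatter. They also leave open what an exchange of the two methoxy groups on the shared core would do.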